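The source may hold more compounds than are shown below. What is called first, only, known or untested is meant among the compounds shown, and "the series" means these compounds.

Values measured in an ADME assay on microsomes from liver (Homo sapiens) for metabolic stability, read by LC-MS, using NADPH, with stated times of 5 min and 30 min, tested at 1 uM; on this read-out higher numbers stand for fast clearance and lower numbers for slow clearance:

- compound 1 `CN(c1ccccc1)c1cnc(NCc2c(F)ccc3c2CCO3)n2cnnc12`: 55 mL.min-1.g-1
- compound 2 `O=C(Nc1cnc(NCc2c(F)ccc3c2CCO3)n2cnnc12)c1ccccc1`: 10 mL.min-1.g-1
- compound 3 `O=C1CCCN1c1cnc(NCc2c(F)ccc3c2CCO3)n2cnnc12`: < 3 mL.min-1.g-1

Compound 3 has the lowest reading of the three, and its < 3 mL.min-1.g-1 is a limit of the assay and not a number.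

Compound 4 `Fc1ccc2c(c1CNc1ncc(Nc3ccccc3)c3nncn13)CCO2` has not yet been measured. It differs from compound 3 by this change: anilino in place of 2-oxopyrrolidin-1-yl on an aromatic carbon.

Among the compounds with values here, two measured steps bear on it, both introducing the group that compound 4 gives up: an at least 18-fold lower number from compound 1 to compound 3 (1.26 log units; beyond the scatter), and an at least 3.3-fold lower number from compound 2 to compound 3 (0.52 log units; beyond the scatter). Reversing that kind of change suggests a rise in this assay, of modest to large size and beyond the scatter. The expected size is an at least 8.3-fold higher number from compound 3 to compound 4 (0.92 log units; beyond the scatter). For compound 4 the estimated value is 25 mL.min-1.g-1, with an expected range of 9 mL.min-1.g-1 to 70 mL.min-1.g-1.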

Compound 4, intrinsic clearance in microsomes in the Homo sapiens assay: 20 mL.min-1.g-1
Compound 4: the middle estimate sits 1.3-fold (0.10 log units) above what was measured; the measured number falls inside the stated range.
By their numbers in the Homo sapiens assay, from the lowest: compounds 2 and 4 (each within the scatter of the next); then compound 1. At a limit, below all of these: compound 3.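

In the Homo sapiens assay, anilino in place of 2-oxopyrrolidin-1-yl on this aromatic carbon gives an at least 6.6-fold higher number from compound 3 to compound 4 (0.82 log units; beyond the scatter). The reading of compound 3, < 3 mL.min-1.g-1, is a limit of the assay. Hydrogen in place of methyl on the nitrogen gives a 2.8-fold lower number from compound 1 to compound 4 (0.44 log units; beyond the scatter), whereas phenyl in place of benzoyl on that nitrogen gives a 2.0-fold higher number from compound 2 to compound 4 (0.30 log units; within the scatter), so the carbonyl shows no readable effect here.

In a physicochemical assay for lipophilicity, using the shake flask method, in phosphate buffer, measured as octanol-water partition, with a stated time of 30 min, at pH 7.4 (on this read-out higher numbers stand for higher lipophilicity and lower numbers for lower lipophilicity), compound 3 gives 1.3 and compound 4 gives 3.3. Within the data shown here, whether clearance follows lipophilicity stays open, since only one pair is available in the physicochemical assay: the measured distribution coefficient of compound 3, 1.3, and of compound 4, 3.3, a number 2.00 log units higher (beyond the scatter). As far as these compounds go, how an acetamido group or a morpholine would read at this position also remains open.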